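Fluoro in Place of Chloro on the Alkyne-Bearing Ring

The source may report more compounds than this note shows. Statements on the series, on what has been measured and on what is new or still open speak of the compounds shown alone.

Compound 1 `CN(C)CC#Cc1ccc(OCCCc2sc(N3CCc4cccc(C(=O)Nc5nc6ccccc6s5)c4C3)nc2C(=O)O)cc1` is the anchor of this comparison. For the measured compounds named here, in an assay on isolated protein for inhibition of Apoptosis regulator Bcl-2 (Homo sapiens), read by TR-FRET, with a stated time of 1 h (on this read-out lower numbers stand for stronger inhibition and higher numbers for weaker inhibition), compound 1 gives 60 nM, the lowest of the two numbers measured so far. Its nearest neighbour, compound 2 `CN(C)CC#Cc1ccc(OCCCc2sc(N3CCc4cccc(C(=O)Nc5nc6ccccc6s5)c4C3)nc2C(=O)O)c(Cl)c1`, carries chloro in place of hydrogen on an aromatic carbon of the same ring; in this assay compound 2 gives 280 nM, and the step of a 4.7-fold higher number from compound 1 to compound 2 (0.67 log units; beyond the scatter) lies beyond the scatter and counts as a modest loss.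

The unmeasured compound 3 `CN(C)CC#Cc1ccc(OCCCc2sc(N3CCc4cccc(C(=O)Nc5nc6ccccc6s5)c4C3)nc2C(=O)O)cc1F` differs from compound 1 in one place: fluoro in place of hydrogen on an aromatic carbon. Going by the values given here, only one measured step bears on this change, the one in which chloro entered the same ring and a 4.7-fold higher number from compound 1 to compound 2 (0.67 log units; beyond the scatter) was recorded. The entering group in compound 3 is again a single halogen atom, and the expectation is a shift in the same direction but of smaller size, the estimated step of a 1.7-fold higher number from compound 1 to compound 3 (0.22 log units; within the scatter) staying close to the scatter. Compound 3 is therefore expected to give about 100 nM in this assay, with a range from 50 nM to 250 nM.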

Compound 3, inhibition constant: 88 nM
Compound 3: middle estimate off by 1.1-fold (0.06 log units), on the high side; low and high end bracket the measured number.
By their numbers in this assay, from the lowest: compounds 1 and 3 (each within the scatter of the next); then compound 2.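

In this assay, fluoro in place of hydrogen on the aromatic carbon ortho to the 3-(dimethylamino)prop-1-yn-1-yl group leaves the number within the scatter of the parent (a 1.5-fold higher number from compound 1 to compound 3 (0.17 log units; within the scatter)), so compound 1 and compound 3 cannot be told apart in this assay. The earlier compounds had shown only a single halogen substitution on this ring, chloro, with a loss beyond the scatter (a 4.7-fold higher number from compound 1 to compound 2 (0.67 log units; beyond the scatter)); the new result shows that a halogen on this ring need not bring such a loss, although compound 2 and compound 3 differ in both the halogen and the ring carbon that carries it. Nothing available accounts for the difference between these two steps.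

The compounds shown leave open whether the outcome depends on the halogen or on its place, since neither chloro on the carbon ortho to the 3-(dimethylamino)prop-1-yn-1-yl group nor fluoro on the carbon that carries chloro in compound 2 appears among them. They also leave open how a methyl, a methoxy or a nitrile would read at the position taken by fluoro in compound 3.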